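This account rests on a few compounds, and the source may have more. Where it says the series, first, only, none or still open, it means among the compounds named here.

Measured compounds:
- Compound 1, `Cc1ccccc1-n1c(C)cc(C(=O)O)c1C`: 2200 nM
- Compound 2, `Cc1cc(C(=O)O)c(C)n1-c1ccccc1Cl`: 2300 nM
- Compound 3, `Cc1cc(C(=O)O)c(C)n1-c1cccc(Cl)c1Cl`: 220 nM

In an assay on cells for inhibition of Palmitoleoyl-protein carboxylesterase NOTUM variant C330S (Homo sapiens), read by fluorescence, with a stated time of 40 min (a higher number here means a weaker inhibitor, a lower number a stronger inhibitor), compound 2 gives 2300 nM. Among the three numbers this is the highest, yet compound 1 sits so close that the two cannot be told apart: a 1.0-fold higher number from compound 1 to compound 2 (0.02 log units; within the scatter). Compound 3 is the far end, reached by a 10-fold lower number from compound 2 to compound 3 (1.02 log units; beyond the scatter).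

Compound 4, `Cc1cc(C(=O)O)c(C)n1-c1ccc(Cl)cc1Cl`, is not yet measured. It differs from compound 2 by chloro in place of hydrogen on an aromatic carbon; the new chloro sits on the six-membered aromatic ring of carbon only, meta to a chloro group and para to a large group.

Going by the values given here, only one measured step has the same kind of change, chloro in place of hydrogen on that ring, namely the large step from compound 2 to compound 3, where the added chloro sits at a different place on the ring. The step from compound 1 to compound 2 swaps chloro for methyl and stays within the scatter, so it says little here. The place on the ring is not the same, so a lowering in this assay smaller than the measured step is assumed. The expected step for compound 4 in this assay is estimated as a 2.6-fold lower number from compound 2 to compound 4 (0.41 log units; beyond the scatter). Compound 4 is estimated at 900 nM, with a range from 250 nM to 2500 nM.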

Compound 4, half-maximal inhibitory concentration: 430 nM
For compound 4 the middle estimate is 2.1-fold (0.32 log units) above the measured one; measured number inside the range.
By their numbers in this assay, from the lowest: compounds 3 and 4 (each within the scatter of the next); then compounds 1 and 2 (each within the scatter of the next).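

In this assay, adding a chloro to compound 2 at the place meta to a chloro group and para to a large group gives a 5.3-fold lower number from compound 2 to compound 4 (0.73 log units; beyond the scatter). Going by these compounds alone, until now, the only evidence that a second chloro on this ring lowers the number came from compound 3, with its chloro at a different place; compound 4 shows that the lowering is not confined to that one place. Compound 3 at 220 nM and compound 4 at 430 nM lie within the scatter of each other, so this assay does not separate the two places, even though each step from compound 2 lies beyond the scatter.

Nothing available here explains why a chloro at either place lowers the number. The compounds shown also leave open whether this place needs a chloro in particular, since a fluoro, a methyl, a methoxy or an amine there could give a different number, and whether a third chloro on the same ring would lower the number further.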